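Benzyl variation on a spiro piperidine modulator of N1303K

This account rests on a few compounds, and the source may have more. Where it says the series, first, only, none or still open, it means among the compounds named here.

Measured so far:
Compound 1, `COc1ccc2[nH]c3c(c2c1)CCNC31CCN(Cc2ccc(Cl)cc2Cl)CC1`: 1800 nM
Compound 2, `COc1ccc2[nH]c3c(c2c1)CCNC31CCN(Cc2ccccc2Cl)CC1`: 2200 nM
Compound 3, `COc1ccc2[nH]c3c(c2c1)CCNC31CCN(Cc2cccc(F)c2F)CC1`: 13600 nM

The three compounds share one core and differ only in the aromatic group on the saturated chain carbon bound to an amine nitrogen in a ring. In an assay on FRT cells for positive allosteric modulation of Cystic fibrosis transmembrane conductance regulator variant N1303K (Homo sapiens), in the presence of a further agent that is not named here (a lower number here means that less compound is needed, a higher number that more compound is needed for the effect), compound 1 gives the lowest of the three numbers. Compound 2 lies close to it, as the step of a 1.2-fold higher number from compound 1 to compound 2 (0.09 log units; within the scatter) shows, so the two cannot be ordered. Compound 3 stands apart: the step of a 7.6-fold higher number from compound 1 to compound 3 (0.88 log units; beyond the scatter) and the step of a 6.2-fold higher number from compound 2 to compound 3 (0.79 log units; beyond the scatter) are both beyond the scatter.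

Compound 4, `COc1ccc2[nH]c3c(c2c1)CCNC31CCN(Cc2ccco2)CC1`, has not yet been measured. Its change from compound 1 is furan-2-yl in place of 2,4-dichlorophenyl on a saturated chain carbon bound to an amine nitrogen in a ring. Among the compounds with values here, no measured step puts a five-membered aromatic ring with one hetero atom in this place, so the bearing of the known steps is indirect. The step of a 1.2-fold higher number from compound 1 to compound 2 (0.09 log units; within the scatter) says that losing one chloro costs little, while the step of a 7.6-fold higher number from compound 1 to compound 3 (0.88 log units; beyond the scatter) says that exchanging the 2,4-dichlorophenyl for another substituted ring can cost a modest amount. As compound 4 loses both chlorines and the six-membered ring itself, an increase beyond the scatter is expected, a 4.4-fold higher number from compound 1 to compound 4 (0.65 log units; beyond the scatter). For compound 4 the estimate in this assay is 8000 nM, with a range from 2500 nM to 25000 nM.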

Compound 4, half-maximal effective concentration: 16400 nM
Compound 4: middle estimate off by 2.1-fold (0.31 log units), on the low side; the measured number falls inside the stated range.
By their numbers in this assay, from the lowest: compounds 1 and 2 (each within the scatter of the next); then compounds 3 and 4 (each within the scatter of the next).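

In this assay, the place on a saturated chain carbon bound to an amine nitrogen in a ring proves open to a five-membered aromatic ring with 1 hetero atom only at a cost: furan-2-yl in place of the chlorinated rings gives two steps beyond the scatter (a 9.1-fold higher number from compound 1 to compound 4 (0.96 log units; beyond the scatter)) and (a 7.5-fold higher number from compound 2 to compound 4 (0.87 log units; beyond the scatter)). Against the 2,3-difluorophenyl group, furan-2-yl makes no readable difference (a 1.2-fold higher number from compound 3 to compound 4 (0.08 log units; within the scatter)), so two quite different rings without chlorine now stand together, and across these four compounds the two bearing chlorine, compound 1 and compound 2, give the lower numbers, with none going against this. No measurement bears on why the compounds fall into these two groups.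

The compounds shown leave open whether a plain phenyl group would sit with compound 1 and compound 2 or with compound 3 and compound 4, which would tell whether chlorine or the fluorine atoms decide the difference among the six-membered rings. They also leave open whether thiophen-2-yl, with sulfur in place of the furan oxygen, would differ from compound 4.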